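Swapping an amidine-type group for methoxy on a fused core

The compounds below may be only part of what the source reports. "The series", "measured", "known", "first", "only" and "open" are said of these compounds alone.

In a functional assay on the whole organism with Rattus norvegicus as the target (on this read-out higher numbers stand for an effect only at larger amounts of compound and lower numbers for an effect already at smaller amounts), two compounds have been measured so far. Compound 2 `Cc1nc2c(OCc3ccccc3)cccn2c1/N=C/N(C)C` gives 9.8 mg/kg. Compound 1 `Cc1nc2cccc(CCc3ccccc3)n2c1N` differs from compound 2 at several places. Compound 1 gives 14 mg/kg. These two numbers lie within the usual scatter of each other, so the data do not tell the two compounds apart.

Compound 3 `COc1c(C)nc2c(OCc3ccccc3)cccn12` has not yet been measured. It is compound 2 with one change: a group of 2 heavy atoms (1 carbon, 1 oxygen; no ring) in place of a group of 5 heavy atoms (3 carbon, 2 nitrogen; no ring), on an aromatic carbon. The group that leaves carries one double bond outside aromatic rings and one hydrogen-bond acceptor; the methoxy that enters keeps one hydrogen-bond acceptor but is much smaller.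

Going by the values given here, no pair of measured compounds shows the effect of this change on its own, so any expectation rests on the change itself rather than on a measured step. Compound 3 is estimated to show a modest loss, an expected step of a 1.6-fold higher number from compound 2 to compound 3 (0.21 log units; within the scatter), though a result within the scatter would not be surprising. On this basis compound 3 is expected to give about 16 mg/kg, with a plausible range from 5 mg/kg to 50 mg/kg.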

Compound 3, dose for half-maximal effect: 3.6 mg/kg
For compound 3 the middle estimate is 4.4-fold (0.65 log units) above the measured one; the whole stated range lies above it.
By their numbers in this assay, from the lowest: compound 3; then compounds 2 and 1 (each within the scatter of the next).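

Going by these compounds alone, compound 1 differs from compound 2 at several places, so it could not show what this position does; the new pair gives the first reading of a single change on the shared core. On the aromatic carbon of the five-membered ring, next to the ring nitrogen, methoxy in place of the open-chain group of 5 heavy atoms gives a 2.7-fold lower number from compound 2 to compound 3 (0.43 log units; beyond the scatter) in this assay and so shifts the effect to smaller amounts of compound, which shows that on this core the larger group with its double bond outside the aromatic rings is not needed for an effect in this whole-animal read-out. No measurement here explains this result.

On these data alone, whether the shift belongs to methoxy itself or would come with any small group at this place stays open, and ethoxy, a chlorine atom or a plain hydrogen there would help to settle it. As far as these compounds go, it is also open whether the same swap would give a similar step on a compound carrying the side chain of compound 1 instead of the benzyloxy group.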